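A few compounds are considered here, and "the series" means these few. Any claim that something is new, unique, unknown or untested is made for them only; others in the source may bear on it.

Series notes. Compound 1 `CCOC(=O)[C@H](CCC(=O)O)NC(=O)c1ccc(CNc2nc3cc(N)cc(N)c3nc2-c2ccccc2)cc1`, compound 2 `CCOC(=O)[C@H](CCC(=O)O)NC(=O)c1ccc(Sc2nc3cc(N)cc(N)c3nc2-c2ccccc2)cc1` and compound 3 `COc1ccc(Sc2nc3cc(N)cc(N)c3nc2-c2ccccc2)cc1` share one core and have each been run in a functional assay on U-251 cells (Homo sapiens) for inhibition, read by sulforhodamine B assay, with a stated time of 48 h; on this read-out higher numbers stand for lower toxicity in this test and lower numbers for higher toxicity in this test. For compound 1 the result is a limit of the assay, < 100000 nM. For compound 2 the result is likewise a limit, < 100000 nM. Compound 3 also gives only a limit, < 100000 nM, so where it stands among the numbers shown cannot be ranked: the limit of < 100000 nM in this assay, at which 3 of the 3 values shown sit. Compound 4 `Nc1cc(N)c2nc(-c3ccccc3)c(Oc3ccc(F)cc3)nc2c1` is not yet measured; it differs from compound 3 by 4-fluorophenoxy in place of (4-methoxyphenyl)sulfanyl on an aromatic carbon. Going by the values given here, with no measured step between two numbered values in this set, there is no basis for expecting a step of any size beyond the scatter in this assay; the expected step that the limit leaves unreadable from compound 3 to compound 4 is set near none. For compound 4 the estimate in this assay is 20000 nM, within a range from 5000 nM to 80000 nM, with a fair chance that only a limit is reported again.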

Compound 4, concentration lethal to 50% of the cells: < 100000 nM
Compound 4 ended at the assay's limit (the forecaster's own chance of this, stated with the estimate: 50%); the middle value lies beyond the limit too.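

Compound 4, like compound 3, gives only a limit, so no step between compound 3 and compound 4 can be read: the limit of < 100000 nM in this assay, at which 4 of the 4 values shown sit.

The compounds shown leave open whether 4-fluorophenoxy in place of (4-methoxyphenyl)sulfanyl changes the read-out at all.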